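Adding a second nitro group to a thiourea-linked benzothiazole

The compounds below may be only part of what the source reports. "The series", "measured", "known", "first", "only" and "open" are said of these compounds alone.

Measured so far, in a functional assay on HeLa cells (Homo sapiens) for cytotoxicity, read by MTT assay, with a stated time of 24 h; on this read-out lower numbers stand for stronger inhibition and higher numbers for weaker inhibition:
- Compound 1 `Nc1ccc2sc(NC(=S)NC(=O)c3ccc([N+](=O)[O-])cc3)nc2c1`: 63100 nM
- Compound 2 `O=C(NC(=S)Nc1nc2cc([N+](=O)[O-])ccc2s1)c1ccccc1`: 75100 nM
- Compound 3 `O=C(NC(=S)Nc1nc2cc(Br)ccc2s1)c1ccccc1`: 64600 nM

Compound 2 gives the highest number of the three in this assay, but its nearest neighbours sit close: compound 3 is only a 1.2-fold lower number from compound 2 to compound 3 (0.07 log units; within the scatter) away, a step made by swapping bromo in place of nitro on an aromatic carbon of the shared core, and compound 1 sits a similarly small distance away. None of these gaps exceeds the usual scatter, so the three compounds cannot be ranked on these numbers.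

Compound 4 `O=C(NC(=S)Nc1nc2cc([N+](=O)[O-])ccc2s1)c1ccc([N+](=O)[O-])cc1` differs from compound 2 by nitro in place of hydrogen on an aromatic carbon; the group is placed para to a large group on the six-membered carbon ring. Among the measured compounds shown here, only one measured step bears on this change, and it tests the other end of the molecule: the swap from compound 2 to compound 3 stayed within the scatter. Compound 1 already carries the 4-nitrophenyl group and its value lies within the scatter of compound 2. Nothing therefore points to a shift beyond the scatter in this assay.

Compound 4 is expected to land at 65000 nM, within 30000 nM to 140000 nM, an expected step of a 1.2-fold lower number from compound 2 to compound 4 (0.06 log units; within the scatter).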

Compound 4, half-maximal inhibitory concentration: 68500 nM
The estimate for compound 4 lay 1.1-fold (0.02 log units) below the measured number; the range from low to high includes it.
By their numbers in this assay, from the lowest: compounds 1, 3, 4 and 2 (each within the scatter of the next).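

In this assay, the swap of phenyl to 4-nitrophenyl, with the nitro group para to a large group, gives a 1.1-fold lower number from compound 2 to compound 4 (0.04 log units; within the scatter). Among the compounds shown here, this is the first measured step at this end of the molecule, since the earlier step between compound 2 and compound 3 concerned only the shared core, and the two compounds cannot be told apart here even though one carries an extra nitro group. With the 4-nitrophenyl group held constant, nitro in place of amino on an aromatic carbon of the core gives a 1.1-fold higher number from compound 1 to compound 4 (0.04 log units; within the scatter), so this second comparison also yields no readable difference, and no measurement is available to explain either result.

From the compounds shown here alone, only hydrogen and nitro have been compared at this position on the phenyl ring, so it remains open whether an amine, a carboxylic acid or a longer chain placed there would move the number beyond the scatter. A single pair also cannot show whether the same swap would behave alike on a core carrying bromo or amino rather than nitro.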